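Swapping a chloro for an amino on a purine-like core

A few compounds are considered here, and "the series" means these few. Any claim that something is new, unique, unknown or untested is made for them only; others in the source may bear on it.

Of the compounds shown here, three have been measured in an assay on isolated protein for inhibition of Rho-associated protein kinase 1 (Homo sapiens), tested at 30 uM; on this read-out higher numbers stand for more inhibition at the one concentration tested (going by the name of the read-out) and lower numbers for less inhibition. Compound 1 `Clc1ncnc2c1ncn2Cc1ccccc1` gives 3%. Compound 2 `Clc1ncnc2ncn(Cc3ccccc3)c12`, which carries the same groups arranged differently on the shared core, gives 6%. Compound 3 `Fc1ccc(Cn2cnc3ncnc(Cl)c32)cc1` gives 7%, a number that sits close to both others: the change a number 1 percentage points higher from compound 2 to compound 3 (within the scatter), and the gap to compound 1 is likewise within the scatter, so the three numbers cannot be told apart in this assay.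

Compound 4 `Nc1ncnc2ncn(Cc3ccc(F)cc3)c12` differs from compound 3 in a single spot: amino in place of chloro on an aromatic carbon. Going by the values given here, none of the measured steps involves this kind of exchange; the only step available, from compound 2 to compound 3, concerns a fluoro on the benzyl ring and left the number essentially unchanged. There is therefore no measured basis for expecting a large move in either direction, and the three measured numbers all lie near the bottom of the scale.

Compound 4 is expected to give a value close to that of compound 3, with the step of a number 1 percentage points higher from compound 3 to compound 4 (within the scatter) expected to stay within the scatter. The estimate for compound 4 is 8%, with a range from 0% to 25%.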

Compound 4, a percentage reported as inhibition, at one concentration (the size of the read-out at that concentration, not a potency): 6%
Compound 4: middle estimate off by 2 percentage points, on the high side; measured number inside the range.
By their numbers in this assay, from the lowest: compounds 1, 2, 4 and 3 (each within the scatter of the next).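

In this assay, amino in place of chloro gives a number 1 percentage points lower from compound 3 to compound 4 (within the scatter), on an aromatic carbon of the six-membered aromatic ring with 2 nitrogen. Going by these compounds alone, this is the first look at this position, as the earlier comparison concerned only a fluoro on the benzyl ring, and it shows that this exchange leaves no change that can be read, even though the entering amino has 1 hydrogen-bond donor and 1 hydrogen-bond acceptor and the leaving chloro has neither. Nothing available explains this result or links it to any property of either group.

The compounds shown leave open whether other groups at this same carbon, such as a methylamino, a methoxy or a longer amine chain, would give a number clearly away from the low values seen so far. From the compounds shown here alone, it also remains open whether amino in place of chloro would give the same outcome with a benzyl ring that has no fluoro, or with the groups arranged on the shared core as in compound 1.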